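Moving the nitro group on the sulfonyl aryl

This account rests on a few compounds, and the source may have more. Where it says the series, first, only, none or still open, it means among the compounds named here.

Compound 1 `O=C(/C=C/c1cn(S(=O)(=O)c2ccc([N+](=O)[O-])cc2)c2ccccc12)c1ccncc1` shows no measurable effect within the reach of the assay: in an ADME assay on HEK293 cells (Homo sapiens) for antiproliferative activity, read by MTT assay, with a stated time of 48 h (a lower number here means a stronger inhibitor, a higher number a weaker inhibitor), compound 1 gives > 150000 nM, which is a limit of the assay. Compound 2 `O=C(/C=C/c1cn(S(=O)(=O)c2cccc3ccccc23)c2ccccc12)c1ccncc1` likewise gives > 150000 nM in this assay, again a limit. The step that the two limits leave unreadable from compound 1 to compound 2 is therefore of unreadable size; both values sit at the limit of > 150000 nM in this assay, at which 2 of the 2 values shown sit. Compound 3 `O=C(/C=C/c1cn(S(=O)(=O)c2ccccc2[N+](=O)[O-])c2ccccc12)c1ccncc1` differs from compound 1 by 2-nitrophenyl in place of 4-nitrophenyl on a sulfonyl sulfur. Within the data shown here, no measured step bears readably on this change, so compound 3 is expected to remain near the limit, with a step that the limit leaves unreadable from compound 1 to compound 3. Compound 3 is thus estimated at 200000 nM, within 100000 nM to 400000 nM.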

Compound 3, half-maximal inhibitory concentration: > 150000 nM
Compound 3: no number, only a limit (the forecaster's own chance of this, stated with the estimate: 80%); the middle value does not contradict the limit.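

No step can be read among compound 1, compound 2 and compound 3, because all three stop at one limit of this assay: the limit of > 150000 nM in this assay, at which 3 of the 3 values shown sit. How far any aryl group on the sulfonyl sulfur shifts activity remains open: none of the compounds shown gives a number.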